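This account rests on a few compounds, and the source may have more. Where it says the series, first, only, none or still open, it means among the compounds named here.

Compound 3 `COc1ncc(-c2ccc3nc(NC(=O)N4CCCC4)nn3c2)cc1NS(=O)(=O)c1ccc(F)cc1` gives 3570 nM in a functional assay on A549 cells (Homo sapiens) for cytotoxicity, read by MTT assay, with a stated time of 72 h (on this read-out lower numbers stand for stronger inhibition and higher numbers for weaker inhibition), the highest of the three numbers recorded; compound 1 `CCCNC(=O)Nc1nc2ccc(-c3cnc(OC)c(NS(=O)(=O)c4ccc(F)cc4)c3)cn2n1` gives 220 nM and compound 2 `COc1ncc(-c2ccc3nc(NC(=O)NCCN4CCCC4)nn3c2)cc1NS(=O)(=O)c1ccc(F)cc1` gives 960 nM. Compound 4 `COc1ncc(-c2ccc3nc(NC(=O)N(C)C)nn3c2)cc1NS(=O)(=O)c1ccc(F)cc1` differs from compound 3 in one place: dimethylamino in place of pyrrolidin-1-yl on a carbonyl carbon. Within the data shown here, two measured steps bear on this change, since each also alters the group on the carbonyl carbon: a 16-fold higher number from compound 1 to compound 3 (1.21 log units; beyond the scatter) and a 3.7-fold higher number from compound 2 to compound 3 (0.57 log units; beyond the scatter). Both ran in the direction of higher numbers when pyrrolidin-1-yl entered, so removing it may move the number back down, though dimethylamino is neither of the groups it replaced, so a small step or none beyond the scatter is expected. Compound 4 is expected to show a 1.4-fold lower number from compound 3 to compound 4 (0.15 log units; within the scatter). The estimate for compound 4 is 2500 nM, with a range from 900 nM to 7000 nM.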

Compound 4, half-maximal inhibitory concentration: 1190 nM
Compound 4: middle estimate off by 2.1-fold (0.32 log units), on the high side; low and high end bracket the measured number.
By their numbers in this assay, from the lowest: compound 1; then compounds 2 and 4 (each within the scatter of the next); then compound 3.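

Dimethylamino in place of pyrrolidin-1-yl on the carbonyl carbon gives a 3.0-fold lower number from compound 3 to compound 4 (0.48 log units; beyond the scatter) in this assay, so the two ring-free groups at this position do not share the high number of the pyrrolidin-1-yl compound. Dimethylamino in place of (2-(pyrrolidin-1-yl)ethyl)amino stays within the scatter, at a 1.2-fold higher number from compound 2 to compound 4 (0.09 log units; within the scatter). Dimethylamino in place of propylamino still gives a 5.4-fold higher number from compound 1 to compound 4 (0.73 log units; beyond the scatter), so propylamino remains the best group shown here.

On these data alone, whether a piperidine, a morpholine or a butylamino chain on this carbonyl carbon would fall nearer propylamino or pyrrolidin-1-yl stays open. Nothing shown gives a reason for these steps.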